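The compounds below may be only part of what the source reports. "The series", "measured", "known", "first", "only" and "open" are said of these compounds alone.

Of the compounds shown here, two have been measured in an assay on Sf9 cells for inhibition of protein deacetylase HDAC6 (Homo sapiens), read by fluorescence, with a stated time of 40 min, tested at 100 nM; a lower number here means less inhibition, a higher number more inhibition at the concentration tested (going by the name of the read-out). Compound 1 `Cc1ccc(-n2nc(-c3ccccc3)nc2CNc2ccc(C(=O)NO)cc2)cc1` has the higher number of the pair: in this assay compound 1 gives 60.7%, the highest of the two numbers. Compound 2 `NC(=O)c1ccc(NCc2nc(-c3ccccc3)nn2-c2ccccc2)cc1` sits far lower, and in this assay compound 2 gives -4.4%, a gap beyond the usual scatter. Among the compounds with values here, the two structures differ in more than one place, so no single structural change can be tied to that gap, and no step between measured compounds is available to lean on.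

Compound 3 `Cc1cc(C)cc(-n2nc(-c3ccccc3)nc2CNc2ccc(C(=O)NO)cc2)c1` has not yet been measured. It differs from compound 1 in one place: 3,5-dimethylphenyl in place of 4-methylphenyl on an aromatic nitrogen. The change is confined to the group on that ring nitrogen, while the rest of the molecule is kept as in compound 1. With nothing measured for such a swap, the expectation is a step of modest size from compound 1 to compound 3 in this assay, not clearly in either direction and likely within the scatter. The step expected is a number 5.7 percentage points lower from compound 1 to compound 3 (within the scatter). For compound 3 the estimated value in this assay is 55%, with a range from 35% to 75%.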

Compound 3, a percentage reported as inhibition, at one concentration (the size of the read-out at that concentration, not a potency): 49.8%
For compound 3 the middle estimate is 5.2 percentage points above the measured one, and the stated range covers the measured number.
By their numbers in this assay, from the lowest: compound 2; then compound 3; then compound 1.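

Within the data shown here, this is the first step that can be read at a single place: in this assay, putting 3,5-dimethylphenyl in place of 4-methylphenyl on the aromatic nitrogen gives a number 10.9 percentage points lower from compound 1 to compound 3 (beyond the scatter). The group on that nitrogen therefore has a bearing on the read-out, although this change, which adds one carbon and alters where the methyl groups sit, brings only a modest loss and leaves compound 3 with clear inhibition at the concentration tested. Because the swap alters both the number and the placement of the methyl groups, this one step cannot separate those two changes, and nothing available here explains the lower number.

On these data alone, it remains open how this position would respond to a plain phenyl or to a ring carrying a chlorine, a methoxy group or a carboxylic acid, and so whether any such group would lower the number further, hold it or raise it. Each number is also a reading at one concentration rather than a potency, so how this step would translate into a difference in potency is open too.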